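The source may report more compounds than this note shows. Statements on the series, on what has been measured and on what is new or still open speak of the compounds shown alone.

Measured compounds:
Compound 1, `CCCCCc1c(C)nc(N)nc1NCCCC`, gives 1220 nM in an assay on HEK293 cells for agonist activity at Toll-like receptor 8 (Homo sapiens), read by spectrophotometry; on this read-out higher numbers stand for an effect only at larger amounts of compound and lower numbers for an effect already at smaller amounts.
Compound 2, `CCCCNc1nc(N)nc(C)c1CCCn1cccn1`, gives 1050 nM in this assay.

Among the measured compounds shown here, compound 2 has the lowest number of the two measured in this assay, but its nearest neighbour, compound 1, sits so close that the two cannot be told apart: the single measured step, a 1.2-fold lower number from compound 1 to compound 2 (0.07 log units; within the scatter), stays within the scatter. Compound 3, `CCCCNc1nc(N)nc(C)c1CCCCc1ccccc1`, has not been measured. The change from compound 2 to compound 3 is benzyl in place of 1H-pyrazol-1-yl on a saturated chain carbon, three bonds along the chain from an aromatic carbon. For the measured compounds named here, only one measured step bears on it, and that step exchanged a chain end at the same place without moving the number beyond the scatter. The account therefore expects the step of a 1.3-fold lower number from compound 2 to compound 3 (0.12 log units; within the scatter) to stay small as well, with no direction that can be read from the data. The estimate for compound 3 in this assay is 800 nM, within a range from 250 nM to 2500 nM.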

Compound 3, half-maximal effective concentration: 857 nM
The estimate for compound 3 lay 1.1-fold (0.03 log units) below the measured number, within the range that was stated.
By their numbers in this assay, from the lowest: compounds 3, 2 and 1 (each within the scatter of the next).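

The step of a 1.2-fold lower number from compound 2 to compound 3 (0.09 log units; within the scatter) shows that, on a saturated chain carbon three bonds along the chain from an aromatic carbon, a six-membered aromatic ring of carbon only in benzyl cannot be told apart in this assay from the five-membered aromatic ring with 2 hetero atoms in 1H-pyrazol-1-yl. The step of a 1.4-fold lower number from compound 1 to compound 3 (0.15 log units; within the scatter), phenyl in place of methyl on a saturated chain carbon four bonds along the chain from an aromatic carbon, adds that a terminal aromatic ring also stays within the scatter against the plain chain end of compound 1. No measurement is at hand that would explain these results.

From the compounds shown here alone, all three chain ends carry no net charge, so it remains open whether an amine or a carboxylic acid at this place would move the number beyond the scatter. Going by these compounds, whether a longer chain carrying the phenyl ring would do so also remains open.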